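Nitro for hydrogen on the benzoyl ring of compound 3

The source may report more compounds than this note shows. Statements on the series, on what has been measured and on what is new or still open speak of the compounds shown alone.

The measured compounds and their values:
compound 1 `COc1cccc(OCC(=O)Nc2cccc(NC(=O)c3ccc(N(C)C)cc3)c2)c1` gives 5740 nM in an assay on isolated protein for inhibition of Rho-associated protein kinase 2 (Homo sapiens), read by scintillation counting, radiometric assay and 33P incorporation, with a stated time of 40 min, in the presence of a further agent that is not named here; a lower number here means a stronger inhibitor, a higher number a weaker inhibitor;
compound 2 `CC(=O)c1ccc(OCC(=O)Nc2cccc(NC(=O)c3ccc(N(C)C)cc3)c2)cc1F` gives 98 nM in this assay;
compound 3 `O=C(COc1ccc2c(=O)ccoc2c1)Nc1cccc(NC(=O)c2ccccc2)c1` gives 16 nM in this assay.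

Compound 3 stands lowest of the three numbers. Its nearest neighbour is compound 2, which sits a good deal higher, and compound 1 lies furthest above it; both gaps exceed the scatter. Compound 4 `O=C(COc1ccc2c(=O)ccoc2c1)Nc1cccc(NC(=O)c2ccc([N+](=O)[O-])cc2)c1` is the one not yet measured. It differs from compound 3 by nitro in place of hydrogen on an aromatic carbon.

Going by the values given here, only one single-point step is known, a 59-fold lower number from compound 1 to compound 2 (1.77 log units; beyond the scatter), and it concerns the aryl group on the ether oxygen, not the benzoyl ring that changes here. Compounds 1 and 2 carry a dimethylamino group on that ring while compound 3 carries hydrogen, but those pairs differ in other places as well, so their values say nothing clean about this position. Among the compounds with values here, with no step bearing directly on the change, compound 4 is expected to land close to compound 3, with a shift of a 1.3-fold higher number from compound 3 to compound 4 (0.10 log units; within the scatter) in this assay, which is within the scatter. Compound 4 is therefore estimated at 20 nM, with a likely range from 6 nM to 70 nM.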

Compound 4, half-maximal inhibitory concentration: 15 nM
Beside the measured number, compound 4's estimate is 1.3-fold (0.12 log units) above it, within the range that was stated.
By their numbers in this assay, from the lowest: compounds 4 and 3 (each within the scatter of the next); then compound 2; then compound 1.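

In this assay, placing nitro on the aromatic carbon para to a large group gives a 1.1-fold lower number from compound 3 to compound 4 (0.03 log units; within the scatter), so this change from phenyl to 4-nitrophenyl leaves the reading of the pair within the scatter. Going by these compounds alone, this is the first direct look at substitution on the benzoyl ring, since compound 1 and compound 2 carry a dimethylamino group there but differ from compound 3 in other places as well. The pair shows that this carbon can take a group of three heavy atoms, with two hydrogen-bond acceptors, without a change in the number beyond the scatter, but nothing shown accounts for that outcome.

The compounds shown leave open whether an amine or a carboxylic acid on the same carbon would also stay within the scatter of compound 3, and whether a dimethylamino group would do so on the core of compound 3. They also leave open whether nitro would give the same reading on another carbon of the benzoyl ring, or with the 4-acetyl-3-fluorophenyl group of compound 2 on the ether oxygen.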